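The source may hold more compounds than are shown below. What is called first, only, known or untested is meant among the compounds shown, and "the series" means these compounds.

Measured so far in an ADME assay on microsomes from liver (Homo sapiens) for metabolic stability, read by LC-MS, using NADPH, tested at 5 uM; on this read-out lower numbers stand for a shorter-lived compound and higher numbers for a longer-lived compound:
compound 1 `Cc1cc(-c2ccccc2)n(/C(N)=N/S(=O)(=O)c2cc(C)c(Cl)cc2SCc2cccc(C(F)(F)F)c2)n1` gives 0.169 h
compound 2 `Cc1cc(-c2ccccc2)n(/C(N)=N/S(=O)(=O)c2cc(C)c(Cl)cc2SCc2cccc(Cl)c2)n1` gives 0.205 h
compound 3 `Cc1cc(S(=O)(=O)/N=C(\N)n2nccc2-c2ccccc2)c(SCc2ccccc2Cl)cc1Cl` gives 0.226 h

All three values lie within the scatter of one another. From compound 2 to compound 1 the change is trifluoromethyl in place of chloro on an aromatic carbon, and the step is a 1.2-fold lower number from compound 2 to compound 1 (0.08 log units; within the scatter). How the core of compound 2 differs from the core of compound 3 is not broken down here.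

Compound 4 `Cc1cc(S(=O)(=O)/N=C(\N)n2nccc2-c2ccccc2)c(SCc2ccccc2C(F)(F)F)cc1Cl` carries the same kind of change relative to compound 3, (trifluoromethyl in place of chloro on an aromatic carbon). The place is not the same word for word: in compound 3 the group sits ortho to a large group, in compound 2 meta to a large group, so the change is the same kind, not the same.

The step from compound 3 to compound 4 in this assay is expected to be a 1.1-fold lower number from compound 3 to compound 4 (0.05 log units; within the scatter), resting on the small step of a 1.2-fold lower number from compound 2 to compound 1 (0.08 log units; within the scatter). Compound 4 is therefore estimated at 0.2 h, expected to fall between 0.12 h and 0.34 h.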

Compound 4, half-life: 0.15 h
Beside the measured number, compound 4's estimate is 1.3-fold (0.12 log units) above it; the range from low to high includes it.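

In this assay, trifluoromethyl in place of chloro gives a 1.5-fold lower number from compound 3 to compound 4 (0.18 log units; within the scatter). Set beside the earlier step, the change carries from one core to the other with no difference that can be told apart: the same change on two cores in this assay, a 1.2-fold lower number (0.08 log units; within the scatter) from compound 2 to compound 1 and a 1.5-fold lower number (0.18 log units; within the scatter) from compound 3 to compound 4, 1.2-fold (0.09 log units) apart, within the scatter of two such steps. This shows agreement for these two pairs only, with each step within the scatter; it does not show that the two steps are identical, that the change is without effect, or that the agreement extends to other cores or other places on the ring.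

Other groups at this place remain open, such as a nitrile, a methoxy group or an amine. Going by these compounds, a hydrogen in place of chloro also remains open.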